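Sulfone to Sulfide Exchange on a Chalcone-like Scaffold

The source may report more compounds than this note shows. Statements on the series, on what has been measured and on what is new or still open speak of the compounds shown alone.

Compound 1, `COc1cc(OC)c(/C=C(\C(=O)c2ccc(Br)cc2)S(=O)(=O)Cc2ccc(Cl)cc2)c(OC)c1`, gives 25000 nM in a functional assay on DU-145 cells (Homo sapiens) for inhibition, read by trypan blue exclusion, with a stated time of 96 h; a higher number here means a weaker inhibitor of growth, a lower number a stronger inhibitor of growth.
Compound 2, `O=C(/C(=C\c1ccccc1OCc1ccccc1)S(=O)(=O)Cc1ccc(Cl)cc1)c1ccc(Br)cc1`, gives 10000 nM in this assay.
Compound 3, `COc1cc(OC)c(/C=C(/SCc2ccc(F)cc2)C(=O)c2ccc(Br)cc2)c(OC)c1`, gives 1000 nM in this assay.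

Three compounds share a bromophenyl ketone joined through a double bond to a second aromatic ring, and they differ in the group carried on the chain carbon and in the substitution of that second ring. Compound 1 and compound 2 differ in their cores; how the two cores differ is not broken down here, and their values show compound 2 with the lower number. Compound 1 and compound 3 differ in one place, ((4-fluorobenzyl)sulfanyl in place of (4-chlorobenzyl)sulfonyl on a double-bonded chain carbon bound to a carbonyl carbon and a double-bonded chain carbon), and this change gave a 25-fold lower number from compound 1 to compound 3 (1.40 log units; beyond the scatter).

Compound 4, `O=C(/C(=C\c1ccccc1OCc1ccccc1)SCc1ccc(F)cc1)c1ccc(Br)cc1`, has not been measured in this assay. It stands to compound 2 as compound 3 stands to compound 1: the difference is (4-fluorobenzyl)sulfanyl in place of (4-chlorobenzyl)sulfonyl on a double-bonded chain carbon bound to a carbonyl carbon and a double-bonded chain carbon, the same change at the same place. Because that change gave a 25-fold lower number from compound 1 to compound 3 (1.40 log units; beyond the scatter), compound 4 is expected to give a lower number than compound 2. Among the measured compounds shown here, since only one earlier instance exists and the cores of compound 1 and compound 2 are not the same, the step is expected to be somewhat smaller than the earlier one, a 13-fold lower number from compound 2 to compound 4 (1.10 log units; beyond the scatter). Compound 4 is therefore estimated at 800 nM in this assay, with a range from 200 nM to 4000 nM.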

Compound 4, concentration for 50% growth inhibition: 1000 nM
Beside the measured number, compound 4's estimate is 1.3-fold (0.10 log units) below it, and the stated range covers the measured number.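

Carried onto the second core, the change gave a 10-fold lower number from compound 2 to compound 4 (1.00 log units; beyond the scatter) in this assay. The direction of the step was the same on both cores, and its size did not differ between them by more than repeated measurements allow: the same change on two cores in this assay, a 25-fold lower number (1.40 log units; beyond the scatter) from compound 1 to compound 3 and a 10-fold lower number (1.00 log units; beyond the scatter) from compound 2 to compound 4, 2.5-fold (0.40 log units) apart, within the scatter of two such steps This is a result from two cores only, both carrying the bromophenyl ketone, so it supports carrying the change between these two cores but does not show that the step would hold on a core of another kind, nor does it show why the number falls.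

The change joins two exchanges, sulfonyl to sulfanyl and chlorine to fluorine on the benzyl ring, and with no (4-chlorobenzyl)sulfanyl or (4-fluorobenzyl)sulfonyl group among the compounds shown, the share of each in the step remains open. Also open, from the compounds shown here alone, is how the series would respond to other groups at this place, such as an amine, a carboxylic acid or a longer chain in place of the benzyl group.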